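Series notes: compound 4, the amine-free acetamide

The source may hold more compounds than are shown below. What is called first, only, known or untested is meant among the compounds shown, and "the series" means these compounds.

Compound 1 `CN1CCN(CC(=O)Nc2ccc(-c3nc4cc(C(F)(F)F)ccc4n3C)cc2)CC1` carries a ((4-methylpiperazin-1-yl)methyl)carbonyl group, and in an ADME assay on BHK cells (Mesocricetus auratus) for cytotoxicity, read by MTT assay, with a stated time of 96 h (a lower number here means that less compound is tolerated, a higher number that more compound is tolerated), compound 1 gives 16000 nM, the lowest of the two numbers in hand; the nearest is compound 3 `O=C(CN1CCCCC1)Nc1ccc(-c2nc3ccccc3[nH]2)cc1`, which in this assay gives 31000 nM, within the scatter of compound 1. Compound 2 `CC(=O)Nc1ccc(-c2nc3ccccc3[nH]2)cc1` gives only > 100000 nM in this assay, which is a limit of the assay rather than a number, (the limit of > 100000 nM in this assay, at which 1 of the 3 values shown sits). Compound 4 `CC(=O)Nc1ccc(-c2nc3cc(C(F)(F)F)ccc3n2C)cc1` is compound 1 with hydrogen in place of 4-methylpiperazin-1-yl on a saturated chain carbon bound to a carbonyl carbon. Within the data shown here, the one measured step that bears on this is the same kind of change run the other way: an at least 3.2-fold lower number from compound 2 to compound 3 (0.50 log units; beyond the scatter). Read backwards, compound 4 is expected to give a higher number than compound 1, a 3.8-fold higher number from compound 1 to compound 4 (0.57 log units; beyond the scatter). For compound 4 the estimate is 60000 nM, with a range from 25000 nM to 150000 nM, and a limit alone is a real possibility.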

Compound 4, half-maximal cytotoxic concentration: > 100000 nM
Compound 4: no number, only a limit (the forecaster's own chance of this, stated with the estimate: 35%); middle value at least 1.6-fold (0.22 log units) away from the limit.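

Hydrogen in place of 4-methylpiperazin-1-yl on a saturated chain carbon bound to a carbonyl carbon gives an at least 6.2-fold higher number from compound 1 to compound 4 (0.79 log units; beyond the scatter) in this assay. The loss of a ring amine at this position now moves the number upward on a second core, and the step is open-ended, as was an at least 3.2-fold lower number from compound 2 to compound 3 (0.50 log units; beyond the scatter). Compound 4 reads as a limit, not a number, and the amine-free acetamides end there: the limit of > 100000 nM in this assay, at which 2 of the 4 values shown sit.

As far as these compounds go, the true size of both steps stays open. From the compounds shown here alone, whether a morpholine, a dimethylamino group or a longer chain at this position would lower the number as well also remains open.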